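Purine Glycinamide Amino Acid Esters: Oral Tail Flick Notes

The source may report more compounds than this note shows. Statements on the series, on what has been measured and on what is new or still open speak of the compounds shown alone.

Measured compounds:
compound 1 `N=C(N)NCCC[C@H](NC(=O)CN(c1ncnc2c1ncn2C1CCCCO1)C1CC1)C(=O)OCc1ccccc1`: 38.2%
compound 2 `O=C(CN(c1nc(Cl)nc2[nH]cnc12)C1CC1)N[C@@H](CC(=O)OCc1ccccc1)C(=O)OCc1ccccc1`: 12.1%
compound 3 `C[C@@H](O)[C@H](NC(=O)CN(c1nc(Cl)nc2[nH]cnc12)C1CC1)C(=O)O`: 37.6%

Three compounds have been run in a functional assay on the whole organism (Tail, strain ICR) with Mus musculus as the target, in the tail flick test, with a stated time of 120 min, at a dose of 25 umol/kg by the oral route; a lower number here means a weaker effect, a higher number a stronger effect of the compound at the dose given. Compound 1 gives 38.2% and compound 3 gives 37.6%, both well apart from compound 2, which gives 12.1% and stands lowest of the three, with each of the other two values lying beyond the scatter above it.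

Compound 4 `CC(C)[C@H](NC(=O)CN(c1nc(Cl)nc2[nH]cnc12)C1CC1)C(=O)OCc1ccccc1` is not yet measured. It differs from compound 2 in one place: isopropyl in place of (benzyloxycarbonyl)methyl on a saturated chain carbon bound to an amide-type nitrogen and a carbonyl carbon. Going by the values given here, no pair of measured compounds differs in a single place, so no measured step shows what such a change does here. The two nearest neighbours, compound 1 and compound 3, carry other side chains on the same chain carbon and both sit clearly higher than compound 2, so a rise from compound 2 to compound 4 seems the more likely direction, though of uncertain size. The step from compound 2 to compound 4 is estimated at a number 12.9 percentage points higher from compound 2 to compound 4 (beyond the scatter). Compound 4 is expected to give 25%, within 8% to 45%.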

Compound 4, a percentage reported as activity, at one dose (the size of the read-out at that dose, not a potency): 27.3%
Beside the measured number, compound 4's estimate is 2.3 percentage points below it, and the stated range covers the measured number.
By their numbers in this assay, from the lowest: compound 2; then compound 4; then compounds 3 and 1 (each within the scatter of the next).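

The chain carbon bound to an amide-type nitrogen and a carbonyl carbon now has its first readable step: in this assay the pair shows a number 15.2 percentage points higher from compound 2 to compound 4 (beyond the scatter) with isopropyl in place of (benzyloxycarbonyl)methyl. The read-out at this position therefore depends on the side chain, and the six-membered aromatic ring of carbon only in the group that leaves is not required for an effect at this dose. No measured property bears on this change, so the step stands without an explanation.

A single step does not separate the loss of the ester-bearing chain from the gain of the branched isopropyl. A methyl, a butyl or an aminobutyl chain on this carbon, with the rest of compound 4 kept, would show how far the read-out follows the choice of group.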